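Replacing an aryl amide substituent with a small heterocycle

This account rests on a few compounds, and the source may have more. Where it says the series, first, only, none or still open, it means among the compounds named here.

Compound 3 `COc1ccc(NC(=O)COc2cc(C)nc3ccc(OC)cc23)cc1` sits second highest among the three measured values in a physicochemical assay for solubility, in phosphate buffer, measured as kinetic solubility, with a stated time of 1 h, at pH 7.4 (a lower number here means a less soluble compound, a higher number a more soluble compound), with compound 3 giving 108000 nM. Compound 2 `COc1ccc2nc(C)cc(OC3CCN(c4ccccc4)C3=O)c2c1` gives 215000 nM in this assay, and the two values lie within the scatter of each other, so no order can be read between them. Compound 1 `Cc1cc(C)cc(NC(=O)COc2cc(C)nc3ccc(Cl)cc23)c1` gives 8000 nM in this assay, which stands beyond the scatter from compound 3.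

Compound 4 `COc1ccc2nc(C)cc(OCC(=O)NC3CONC3=O)c2c1` has not yet been measured in this assay. It differs from compound 3 at one place: a group of 6 heavy atoms (3 carbon, 1 nitrogen, 2 oxygen; one five-membered non-aromatic ring with 2 hetero atoms) in place of a group of 8 heavy atoms (7 carbon, 1 oxygen; one six-membered aromatic ring of carbon only), on an amide-type nitrogen. The group that enters carries a hydrogen-bond donor and an additional acceptor while the aromatic ring of carbon only is gone.

On these three compounds alone, compound 4 is expected to give a number at or somewhat beyond the upper edge of the scatter relative to compound 3, an estimated step of a 2.0-fold higher number from compound 3 to compound 4 (0.31 log units; beyond the scatter) in this assay. The estimate for compound 4 in this assay is 220000 nM, with a range from 90000 nM to 500000 nM.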

Compound 4, solubility: >= 166000 nM
Compound 4 was reported as a limit (the forecaster's own chance of this, stated with the estimate: 20%); the middle value lies beyond the limit too.
By their numbers in this assay, from the lowest: compound 1; then compounds 3 and 2 (each within the scatter of the next).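

In this assay compound 4 gives >= 166000 nM, which is a limit of the assay and not a number. Among the compounds shown here, the change on the amide-type nitrogen reads as an at least 1.5-fold higher number from compound 3 to compound 4 (0.18 log units; that floor lies within the scatter), so this is the first sign that the 4-methoxyphenyl group can give way to a small five-membered non-aromatic ring with 2 hetero atoms while the reading stays in the range of the highest values shown. How far the true value lies past the floor cannot be read: the limit of >= 166000 nM in this assay, at which 1 of the 4 values shown sits.

Still open, as far as these compounds go, is whether a plain cyclopentyl ring or a short hydroxyethyl chain on the same nitrogen would read alike. The loss of the aromatic ring and the arrival of the hydrogen-bond donor come together in this one change, and the compounds shown do not separate them.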